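Methoxy in place of bromophenyl: expectation for compound 4

The source may hold more compounds than are shown below. What is called first, only, known or untested is meant among the compounds shown, and "the series" means these compounds.

compound 1 `CCC1(c2ccccc2)CC(=O)C(C(CC(=O)c2ccc(-c3ccc(Br)cc3)cc2)c2ccccc2)=C(O)O1`: 6590 nM
compound 2 `CCCC1(c2ccccc2)CC(=O)C(C(CC(=O)c2ccc(-c3ccc(Br)cc3)cc2)c2ccccc2)=C(O)O1`: > 10000 nM
compound 3 `CC1(c2ccccc2)CC(=O)C(C2CC(c3ccc(-c4ccc(Br)cc4)cc3)Cc3ccccc32)=C(O)O1`: 1360 nM

In a functional assay on XF498 cells (Homo sapiens) for inhibition, with a stated time of 72 h (on this read-out higher numbers stand for weaker inhibition and lower numbers for stronger inhibition), compound 1 gives 6590 nM. For compound 2 only a limit of the assay was reached, > 10000 nM. Compound 3 gives 1360 nM, the lowest of the two numbers shown, with compound 1 beyond the scatter above it. Going by the values given here, the single measured step, an at least 1.5-fold higher number from compound 1 to compound 2 (0.18 log units; that floor lies within the scatter), concerns a chain methyl and does not touch an aromatic position, so no measured step bears on the change to compound 4 `COc1ccc(C2Cc3ccccc3C(C3=C(O)OC(C)(c4ccccc4)CC3=O)C2)cc1`, which carries methoxy in place of 4-bromophenyl on an aromatic carbon. With what leaves and what enters so unequal in size, a weaker number is expected. For compound 4 the expected step is a 3.7-fold higher number from compound 3 to compound 4 (0.57 log units; beyond the scatter). Compound 4 is therefore estimated at 5000 nM, between 1500 nM and 15000 nM.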

Compound 4, half-maximal inhibitory concentration: > 10000 nM
Compound 4 ended at the assay's limit; the forecaster's own chance of this, stated with the estimate: 30%; middle value at least 2.0-fold (0.30 log units) away from the limit.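

In this assay, methoxy in place of 4-bromophenyl on this aromatic carbon gives an at least 7.3-fold higher number from compound 3 to compound 4 (0.86 log units; beyond the scatter), so this position is sensitive to the group it carries, which the chain change between compound 1 and compound 2 could not show. The value of compound 4 is a limit of the assay, so the step gives only a floor: the limit of > 10000 nM in this assay, at which 2 of the 4 values shown sit.

On these data alone, whether the loss follows from removing the outer aromatic ring, the bromine or both, or from adding methoxy, stays open. A plain phenyl or an amine on the same carbon would help separate these readings.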